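The source may report more compounds than this note shows. Statements on the series, on what has been measured and on what is new or still open speak of the compounds shown alone.

Three compounds share one core and differ only in the group carried on a saturated chain carbon bound to an amine nitrogen in a ring. Compound 1 `CCOC(=O)c1cnc(N2CCN(Cc3ccc(C(=O)OC)cc3)CC2)nc1Oc1c(C)cc(-c2ccc(C#N)cc2)cc1C` was tested in an ADME assay on MT4 cells (Homo sapiens) for cytotoxicity, read by MTT assay, with a stated time of 4 days (a lower number here means that less compound is tolerated, a higher number that more compound is tolerated), where compound 1 gave only a limit of the assay, > 125000 nM. Compound 2 `CCOC(=O)c1cnc(N2CCN(Cc3ccc(Br)cc3)CC2)nc1Oc1c(C)cc(-c2ccc(C#N)cc2)cc1C` likewise gave only a limit in this assay, > 125000 nM. Compound 3 `CCOC(=O)c1cnc(N2CCN(Cc3ccccc3Br)CC2)nc1Oc1c(C)cc(-c2ccc(C#N)cc2)cc1C` also reached only a limit in this assay, > 125000 nM. As the limit of > 125000 nM in this assay, at which 3 of the 3 values shown sit, records, all three values sit at the same limit, so none of the steps between them can be read: a step that the two limits leave unreadable from compound 1 to compound 2, a step that the two limits leave unreadable from compound 1 to compound 3 and a step that the two limits leave unreadable from compound 2 to compound 3 are each of unknown size. Compound 4 `CCOC(=O)c1cnc(N2CCN(Cc3cccc(OC)c3)CC2)nc1Oc1c(C)cc(-c2ccc(C#N)cc2)cc1C` differs from compound 3 in one place: 3-methoxyphenyl in place of 2-bromophenyl on a saturated chain carbon bound to an amine nitrogen in a ring With no readable measured step, there is no sign of any change beyond the scatter, and the plain expectation is that compound 4 behaves like the others, so the step that the limit leaves unreadable from compound 3 to compound 4 is expected to be close to nothing. Compound 4 is therefore estimated at 200000 nM, between 100000 nM and 500000 nM, most probably again only a limit.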

Compound 4, half-maximal cytotoxic concentration: > 125000 nM
Compound 4: no number, only a limit; the forecaster's own chance of this, stated with the estimate: 85%; the middle value lies beyond the limit too.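

In this assay compound 4 gives only a limit of > 125000 nM and so its steps from compound 1, compound 2 and compound 3 cannot be read: the limit of > 125000 nM in this assay, at which 4 of the 4 values shown sit. The compounds shown leave open at what concentration any of them harms these cells, and whether the group on the chain carbon alters that concentration.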